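The source may report more compounds than this note shows. Statements on the series, on what has been measured and on what is new or still open speak of the compounds shown alone.

Working notes on the series. The three measured compounds share one core and differ in the substituents on the aryl urea side and in the configuration at the saturated ring carbon. Compound 1 `COc1cc(Br)c(NC(=O)N2C=CC(=O)CC2c2ccccc2)cc1OC` is drawn without a configuration at that carbon; in an assay on 1321-N1 cells for antagonist activity at P2X purinoceptor 7 (Homo sapiens), read by FLIPR, with stated times of 20 min, 1 s and 60 s, in the presence of a further agent that is not named here (on this read-out higher numbers stand for weaker inhibition and lower numbers for stronger inhibition), compound 1 gives 39 nM. Compound 2 `COc1cc(C)c(NC(=O)N2C=CC(=O)C[C@H]2c2ccc(F)cc2)cc1OC` gives 12 nM in this assay. Compound 3 `COc1cc(NC(=O)N2C=CC(=O)C[C@H]2c2ccccc2)c(Br)cc1Cl` gives 33 nM in this assay; among the three numbers it stands second highest, its nearest neighbour being compound 1, within the scatter, and its furthest compound 2, which sits beyond the scatter below it.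

Compound 4 `COc1cc(NC(=O)N2C=CC(=O)C[C@@H]2c2ccccc2)c(Br)cc1Cl` is the next step from compound 3: the two compounds have the same atoms and bonds and differ only in configuration as drawn: 1 of 1 stereo elements differ; a stereocentre at a saturated ring carbon is drawn S in compound 3 and R in compound 4. Among the compounds with values here, no measured pair in this set differs only in that way, so there is no step on record to lean on; the measured compounds with a drawn configuration, compound 2 and compound 3, both carry the S form, and nothing here tells how the R form reads. A change of configuration alone at the single stereocentre is expected to move the number in this assay by a step that may well exceed the scatter, most likely towards weaker inhibition, though the direction is not settled by the data. The estimate for compound 4 is 250 nM in this assay, within a broad range of 30 nM to 3000 nM, which means an expected step of a 7.6-fold higher number from compound 3 to compound 4 (0.88 log units; beyond the scatter).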

Compound 4, half-maximal inhibitory concentration: > 10000 nM
Compound 4 ended at the assay's limit (the forecaster's own chance of this, stated with the estimate: 15%); middle value at least 40-fold (1.60 log units) away from the limit.
By their numbers in this assay, from the lowest: compound 2; then compounds 3 and 1 (each within the scatter of the next). At a limit, above all of these: compound 4.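

Within the data shown here, the only single change on record in this assay is a swap of the drawn configuration at the saturated ring carbon, from S to R, and it gives an at least 300-fold higher number from compound 3 to compound 4 (2.48 log units; beyond the scatter), a large step well beyond the scatter. Compound 4 gives > 10000 nM, which is a limit of the assay and not a number. The earlier compounds could not separate the two forms at this carbon, whereas here the whole step can be put down to that one stereocentre, because nothing else changes: the fact that compounds 3 and 4 differ only in the configuration as drawn

The compounds shown leave open whether the same swap carries the same weight with the other aryl urea substituents, as in compound 2, and how the separate S and R forms of compound 1, drawn without a configuration, would read. They also leave open how far the S form tolerates a change of the group at the saturated ring carbon itself, for instance an amine or a carboxylic acid in place of the phenyl group of compound 3.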